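The source may hold more compounds than are shown below. What is called first, only, known or untested is meant among the compounds shown, and "the series" means these compounds.

The measured compounds, with their readings in a functional assay on the whole organism (Tail, strain ICR) with Mus musculus as the target, in the tail flick test, with a stated time of 90 min, at a dose of 25 umol/kg by the oral route; a higher number here means a stronger effect of the compound at the dose given, a lower number a weaker effect:

Compound 1 `O=C(CN(c1ncnc2c1ncn2C1CCCCO1)C1CC1)NCC(=O)OCc1ccccc1` gives 25.9%.
Compound 2 `NC(=O)C[C@H](NC(=O)CN(c1nc(Cl)nc2[nH]cnc12)C1CC1)C(=O)O` gives 20.1%.
Compound 3 `CC(C)(C)OC(=O)NCCCC[C@H](NC(=O)CN(c1ncnc2c1ncn2C1CCCCO1)C1CC1)C(=O)OCc1ccccc1` gives 32.9%.

Compound 2 stands lowest of the three numbers in this assay; compound 1 sits nearest to it, within the scatter, while compound 3 sits furthest, beyond the scatter. Compound 4 `CC(C)C[C@H](NC(=O)CN(c1nc(Cl)nc2[nH]cnc12)C1CC1)C(=O)O` differs from compound 2 in one place: isopropyl in place of carbamoyl on a saturated chain carbon, two bonds along the chain from an amide-type nitrogen and a carbonyl carbon. Among the measured compounds shown here, the only measured step, a number 7 percentage points higher from compound 1 to compound 3 (within the scatter), concerns a different position and a different pair of compounds, and it lay within the scatter; no measured step touches the carbamoyl to isopropyl exchange. With nothing to point either way, compound 4 is expected to stay close to compound 2, with a step of a number 1.9 percentage points higher from compound 2 to compound 4 (within the scatter) of no size beyond the scatter. Compound 4 is therefore estimated at 22%, between 10% and 35%.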

Compound 4, a percentage reported as activity, at one dose (the size of the read-out at that dose, not a potency): 27%
Compound 4: middle estimate off by 5 percentage points, on the low side, within the range that was stated.
By their numbers in this assay, from the lowest: compounds 2, 1, 4 and 3 (each within the scatter of the next, the first and the last beyond it).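

In this assay, carbamoyl and isopropyl were compared directly on the saturated chain carbon, two bonds along the chain from an amide-type nitrogen and a carbonyl carbon, and the exchange gives a number 6.9 percentage points higher from compound 2 to compound 4 (within the scatter). At this place, then, replacing carbamoyl, with its hydrogen-bond donor and acceptor, by isopropyl, with neither, leaves the step inside the scatter. No evidence is available to explain this reading. As far as these compounds go, whether an amine or a longer chain here would produce a step beyond the scatter remains open. So does whether the same exchange would read alike at another dose.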